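The source may hold more compounds than are shown below. What is called first, only, known or untested is meant among the compounds shown, and "the series" means these compounds.

Measured compounds:
- compound 1 `COc1ccc(CNCc2c(OC)cc(Oc3cccc(Nc4ccccc4)c3)cc2OC)cc1` gives 2650 nM in a functional assay on HCT-15 cells (Homo sapiens) for inhibition, read by MTT assay, with a stated time of 72 h; a lower number here means a stronger inhibitor, a higher number a weaker inhibitor
- compound 2 `COc1cc(Oc2cccc(Nc3ccccc3)c2)cc(OC)c1CNCc1ccccc1` gives 5020 nM in this assay
- compound 3 `COc1cc(Oc2cccc(Nc3ccccc3)c2)cc(OC)c1CNCCNC(C)=O` gives 5090 nM in this assay

Compound 3 has the highest of the three numbers, though the steps of a 1.0-fold higher number from compound 2 to compound 3 (0.01 log units; within the scatter) and a 1.9-fold higher number from compound 1 to compound 3 (0.28 log units; within the scatter) both lie within the scatter. Compound 4 `COc1cc(Oc2cccc(Nc3ccccc3)c2)cc(OC)c1CNCc1ccc(Cl)cc1` differs from compound 3 by 4-chlorophenyl in place of acetamidomethyl on a saturated chain carbon bound to an amine nitrogen. Among the measured compounds shown here, the steps that bear on this place, a 1.9-fold higher number from compound 1 to compound 2 (0.28 log units; within the scatter) and a 1.0-fold higher number from compound 2 to compound 3 (0.01 log units; within the scatter), both stayed within the scatter, so no change beyond the scatter is expected in this assay, with if anything a somewhat lower number. Compound 4 is therefore estimated at 3800 nM, between 1600 nM and 9000 nM, a step of a 1.3-fold lower number from compound 3 to compound 4 (0.13 log units; within the scatter).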

Compound 4, half-maximal inhibitory concentration: 4850 nM
Compound 4: middle estimate off by 1.3-fold (0.11 log units), on the low side, within the range that was stated.
By their numbers in this assay, from the lowest: compounds 1, 4, 2 and 3 (each within the scatter of the next).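

In this assay, 4-chlorophenyl in place of acetamidomethyl on a saturated chain carbon bound to an amine nitrogen stays within the scatter (a 1.0-fold lower number from compound 3 to compound 4 (0.02 log units; within the scatter)), so a group with an aromatic ring and one with no ring are not told apart at this position. Chloro in place of hydrogen (a 1.0-fold lower number from compound 2 to compound 4 (0.01 log units; within the scatter)) and chloro in place of methoxy (a 1.8-fold higher number from compound 1 to compound 4 (0.26 log units; within the scatter)) also stay within the scatter, so hydrogen, methoxy and chloro on that aromatic carbon are not told apart either. No evidence is at hand that would explain these results. Going by these compounds, whether a carboxylic acid, a free amine or a longer chain at this position would move the number beyond the scatter remains open.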